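The compounds below may be only part of what the source reports. "The series", "measured", "known", "first", "only" and "open" are said of these compounds alone.

In an ADME assay on HepG2 cells (Homo sapiens) for cytotoxicity, read by luminescence, with a stated time of 72 h (a lower number here means that less compound is needed, a higher number that more compound is needed for the effect), compound 1 (`CCOC(=O)c1c(-c2cccc(Oc3ccccc3)c2)[nH]c2cc(OC)c(F)cc2c1=O`) gives > 21500 nM as a limit and not a number. Compound 2 (`COc1cc2[nH]c(-c3cccc(Oc4ccccc4)c3)c(C(=O)NCCN3CCCC3)c(=O)c2cc1F`) gives > 21500 nM as a limit too. Compound 3 (`COc1cc2[nH]c(-c3cccc(Oc4ccccc4)c3)c(C(=O)NCCCN3CCCC3)c(=O)c2cc1F`) gives > 21500 nM as a limit as well, so its standing is known only as a limit. The series sits together (the limit of > 21500 nM in this assay, at which 3 of the 3 values shown sit).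

Compound 4 (`COCCOC(=O)c1c(-c2cccc(Oc3ccccc3)c2)[nH]c2cc(OC)c(F)cc2c1=O`) differs from compound 3 by 2-methoxyethoxy in place of (3-(pyrrolidin-1-yl)propyl)amino on a carbonyl carbon on a carbonyl carbon. The closest measured changes join the ethoxy compound 1 to the amides (a step that the two limits leave unreadable from compound 1 to compound 3; a step that the two limits leave unreadable from compound 1 to compound 2), and neither gives a size. No direction can be drawn from them. The expected step (a number no higher from compound 3 to compound 4 (the limit leaves the size open)) is none beyond the scatter in this assay. The value expected for compound 4 is 21500 nM (estimated range 12000 nM to 40000 nM).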

Compound 4, half-maximal effective concentration: > 21500 nM
Compound 4: a limit, no number; the forecaster's own chance of this, stated with the estimate: 85%; the middle value sits exactly at the limit.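

The steps from compound 1, compound 2 and compound 3 to compound 4 join limit to limit and cannot be read: the limit of > 21500 nM in this assay, at which 4 of the 4 values shown sit.

The compounds shown leave open whether the group on the carbonyl carbon changes the read-out in this assay at all, as none of the four gives a number.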